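The compounds below may be only part of what the source reports. "The series", "measured", "known", "first", "only" and "open" are said of these compounds alone.

Measured compounds and their values:

Compound 1 `Nc1nc2c(c(-c3ccco3)cn2[C@@H]2O[C@H](CO)[C@@H](O)[C@H]2O)c(=O)[nH]1`: > 20000 nM in a functional assay on HepG2 cells (Homo sapiens) for antiproliferative activity, read by XTT assay, with a stated time of 72 h; a higher number here means a weaker inhibitor, a lower number a stronger inhibitor
Compound 2 `Nc1nc2c(c(-c3cc4ccccc4o3)cn2[C@@H]2O[C@H](CO)[C@@H](O)[C@H]2O)c(=O)[nH]1`: > 20000 nM
Compound 3 `Nc1nc(N)c2c(-c3cc4ccccc4o3)cn([C@@H]3O[C@H](CO)[C@@H](O)[C@H]3O)c2n1`: > 20000 nM.

For compound 1 the value in this assay is a limit of the assay and not a number. For compound 2 the value is likewise a limit. For compound 3, too, the value is a limit, and its place among the measured compounds can only be read as a limit, as is the case for the other two. The step from compound 2 to compound 1 is a step that the two limits leave unreadable from compound 2 to compound 1; the change is furan-2-yl in place of 1-benzofuran-2-yl on an aromatic carbon. That this step cannot be read rests on (the limit of > 20000 nM in this assay, at which 3 of the 3 values shown sit). The cores of compound 2 and compound 3 differ in a way that is not broken down here.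

Compound 4 `Nc1nc(N)c2c(-c3ccco3)cn([C@@H]3O[C@H](CO)[C@@H](O)[C@H]3O)c2n1` has not yet been measured in this assay. It stands to compound 3 as compound 1 stands to compound 2, the change being (furan-2-yl in place of 1-benzofuran-2-yl on an aromatic carbon), at a place that matches the earlier one word for word. Since the earlier step left both compounds at the limit, the step from compound 3 to compound 4 is expected to be a step that the limit leaves unreadable from compound 3 to compound 4. Compound 4 is therefore estimated at 30000 nM in this assay, with the expected range running from 15000 nM to 100000 nM, and most likely the assay will again report only a limit.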

Compound 4, half-maximal inhibitory concentration: > 20000 nM
Compound 4 gave a limit, no number; the forecaster's own chance of this, stated with the estimate: 85%; the middle value is on the limit's open side.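

Within the data shown here, compound 4 joins compound 3 at the limit, so the step from compound 3 to compound 4, furan-2-yl in place of 1-benzofuran-2-yl on an aromatic carbon, cannot be read, and no new step emerges. This rests on a single finding: the limit of > 20000 nM in this assay, at which 4 of the 4 values shown sit. The compounds shown leave open whether either group, on either core, changes the result in this assay at all.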